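A Methoxy for Chloro Swap on the Sulfonyl Arm

The compounds below may be only part of what the source reports. "The series", "measured", "known", "first", "only" and "open" are said of these compounds alone.

Of the compounds shown here, three sharing one core have been tested in a functional assay on A549 cells (Homo sapiens) for antiproliferative activity, read by MTT assay, with a stated time of 72 h; a higher number here means a weaker inhibitor, a lower number a stronger inhibitor. Compound 1 `CN(C(=O)C(C)(C)C)c1ccc2[nH]c(-c3n[nH]c4ccccc34)cc2n1` gives 24400 nM. Compound 2 `CN(C(=O)c1ccc(Cl)cc1)c1ccc2[nH]c(-c3n[nH]c4ccccc34)cc2n1` gives 2220 nM, and compound 3 `CN(c1ccc2[nH]c(-c3n[nH]c4ccccc34)cc2n1)S(=O)(=O)c1ccc(Cl)cc1` gives 18200 nM. Compound 3 thus stands with compound 1, since a 1.3-fold lower number from compound 1 to compound 3 (0.13 log units; within the scatter), while it is set apart from compound 2, as an 8.2-fold higher number from compound 2 to compound 3 (0.91 log units; beyond the scatter) and an 11-fold lower number from compound 1 to compound 2 (1.04 log units; beyond the scatter) show.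

Compound 4 `COc1ccc(S(=O)(=O)N(C)c2ccc3[nH]c(-c4n[nH]c5ccccc45)cc3n2)cc1` has not yet been measured. It differs from compound 3 only by methoxy in place of chloro on an aromatic carbon. Within the data shown here, none of the measured steps bears on this change: the steps among compounds 1, 2 and 3 all alter the group attached to the nitrogen on the aromatic ring, and not a substituent on the six-membered aromatic ring of carbon only. The data therefore offer no direct measure for the swap, and no step beyond the scatter is expected in this assay. For compound 4 the expected value is 18000 nM, with a range from 6000 nM to 50000 nM. The expected step is accordingly a 1.0-fold lower number from compound 3 to compound 4 (0.00 log units; within the scatter).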

Compound 4, half-maximal inhibitory concentration: 24300 nM
The estimate for compound 4 lay 1.4-fold (0.13 log units) below the measured number, within the range that was stated.
By their numbers in this assay, from the lowest: compound 2; then compounds 3, 4 and 1 (each within the scatter of the next).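

In this assay, among these compounds, methoxy in place of chloro on an aromatic carbon para to a large group comes to a 1.3-fold higher number from compound 3 to compound 4 (0.13 log units; within the scatter), the first direct reading of a change at this position. Methoxy brings a hydrogen-bond acceptor that chloro lacks, yet this exchange on the sulfonyl arm moves the number by no more than the scatter. The data shown offer no evidence on why the number stays within the scatter for this swap.

As far as these compounds go, it remains open whether the same swap on the 4-chlorophenyl group of compound 2, which carries a carbonyl in place of the sulfonyl, would also stay within the scatter. This single pair also cannot say whether an amine, a carboxylic acid or a hydroxy group on that aromatic carbon would produce a step beyond it.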